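An Ester Side Chain Changed, Its Toxicity Still Unknown

The source may hold more compounds than are shown below. What is called first, only, known or untested is meant among the compounds shown, and "the series" means these compounds.

For the measured compounds named here, compound 1 (`CC/C=C\C[C@H]1C(=O)C=C[C@H]1CC(=O)OCCO`) gives 161 uM in an ADME assay on RAW264.7 cells (Mus musculus) for cytotoxicity, read by MTT assay, with a stated time of 24 h (on this read-out lower numbers stand for higher toxicity in this test and higher numbers for lower toxicity in this test), and stands level with the only other compound measured so far. That compound, compound 2 (`CC/C=C\C[C@H]1C(=O)C=C[C@H]1CC(=O)OCCOCCOCCO`), gives 162 uM on the same read-out. Going by the values given here, the one measured step is a 1.0-fold higher number from compound 1 to compound 2 (0.00 log units; within the scatter) and so shows no change beyond the scatter.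

Compound 3 (`CC/C=C\C[C@H]1C(=O)C=C[C@H]1CC(=O)OC(C)COC`) has not yet been measured. Its difference from compound 1 is 1-(methoxymethyl)ethyl in place of 2-hydroxyethyl on an oxygen next to a carbonyl group and reads in words as 1-(methoxymethyl)ethyl in place of 2-hydroxyethyl on an oxygen next to a carbonyl group. Neither measured compound carries this group, and both keep a free hydroxyl end, so the step to compound 2 bears on the change only loosely. Among the compounds with values here, it is still the sole guide, and it alters the same chain without moving the number. An estimated step of a 1.1-fold lower number from compound 1 to compound 3 (0.03 log units; within the scatter) is therefore expected in this assay and would stay within the scatter. For compound 3 the expected value is 150 uM with an estimated range from 75 uM to 300 uM in this test.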

Compound 3, half-maximal toxic concentration: 161 uM
Compound 3: middle estimate off by 1.1-fold (0.03 log units), on the low side; low and high end bracket the measured number.
By their numbers in this assay, from the lowest: compounds 1, 3 and 2 (each within the scatter of the next).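

In this assay, putting 1-(methoxymethyl)ethyl in place of 2-hydroxyethyl on an oxygen next to a carbonyl group gives no change at the digits printed from compound 1 to compound 3 (within the scatter), so the read-out at this position does not depend on the free hydroxyl end that compound 1 and compound 2 both keep. The group that leaves has 1 hydrogen-bond donor and the group that enters has 0, and the earlier step could not test this difference, which here comes with no shift beyond the scatter. No supporting measurement bears on why the number holds, so the result stands as an observation without an explanation.

All three compounds carry the same core and an ester with a short oxygen-bearing chain, so the flat result holds only for this small set of chains. For the compounds shown here, still open is whether an amine or a carboxylic acid at the end of the chain, an amide in place of the ester, or a chain longer than the one in compound 2 would leave the number in this assay just as level.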